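The source may report more compounds than this note shows. Statements on the series, on what has been measured and on what is new or still open speak of the compounds shown alone.

Compound 1 `COc1ccc(-c2cc3ccccc3[nH]2)cc1NS(=O)(=O)NC(=O)OCC(C)C` is the shared core with an isopropyl group on its chain. In an assay for inhibition of Polyunsaturated fatty acid lipoxygenase ALOX15 (Oryctolagus cuniculus), read by spectrophotometry (a higher number here means a weaker inhibitor, a lower number a stronger inhibitor), compound 1 gives > 50000 nM, which is a limit of the assay rather than a number. Compound 2 `COc1ccc(-c2cc3cc(F)ccc3[nH]2)cc1NS(=O)(=O)NC(=O)OCC(C)C` adds a fluoro in place of a hydrogen on the fused two-ring part of the core; in this assay compound 2 gives 20800 nM. Compound 3 `C=CCOC(=O)NS(=O)(=O)Nc1cc(-c2cc3ccccc3[nH]2)ccc1OC` keeps the core of compound 1 but carries a vinyl in place of the isopropyl on the saturated chain carbon bound to an oxygen next to a carbonyl group; in this assay compound 3 gives 43300 nM. Of the two numbers measured, compound 3 stands highest, with compound 2 below it. The move from isopropyl to vinyl gave an at least 1.1-fold lower number from compound 1 to compound 3 (0.06 log units; that floor lies within the scatter), whereas adding fluoro gave an at least 2.4-fold lower number from compound 1 to compound 2 (0.38 log units; beyond the scatter), a change whose full size is uncertain because it began at the assay limit (the limit of > 50000 nM in this assay, at which 1 of the 3 values shown sits). Compound 4 `C=CCOC(=O)NS(=O)(=O)Nc1cc(-c2cc3cc(F)ccc3[nH]2)ccc1OC` differs from compound 3 by fluoro in place of hydrogen on an aromatic carbon. That is the same change as in the fluoro step already seen, so compound 4 is expected to give a lower number than compound 3, with an estimated step of a 2.5-fold lower number from compound 3 to compound 4 (0.41 log units; beyond the scatter). Compound 4 is estimated at 17000 nM, in a range from 6000 nM to 45000 nM.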

Compound 4, half-maximal inhibitory concentration: 23300 nM
The estimate for compound 4 lay 1.4-fold (0.14 log units) below the measured number; the measured number falls inside the stated range.
By their numbers in this assay, from the lowest: compounds 2, 4 and 3 (each within the scatter of the next, the first and the last beyond it). At a limit, above all of these: compound 1.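

Fluoro in place of hydrogen on this aromatic carbon, part of a fused system of two rings, can now be read between two real numbers rather than from a limit: in this assay it gives a 1.9-fold lower number from compound 3 to compound 4 (0.27 log units; within the scatter), so on this core the step alone cannot be told apart from repeat measurements. Set beside the earlier fluoro step, this second reading does not settle how large the change really is, as the two cannot be compared in size: the same change on two cores in this assay, an at least 2.4-fold lower number (0.38 log units; beyond the scatter) from compound 1 to compound 2 and a 1.9-fold lower number (0.27 log units; within the scatter) from compound 3 to compound 4; the limit leaves it open whether they differ The swap of isopropyl for vinyl can also now be read without a limit, and with fluoro present it gives a 1.1-fold higher number from compound 2 to compound 4 (0.05 log units; within the scatter), which means that in this pair the two chain ends cannot be told apart in this assay, and the two readings of that swap agree no more firmly than this: the same change on two cores in this assay, an at least 1.1-fold lower number (0.06 log units; that floor lies within the scatter) from compound 1 to compound 3 and a 1.1-fold higher number (0.05 log units; within the scatter) from compound 2 to compound 4; the limit leaves it open whether they differ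

What a chlorine atom or a methyl group on the same aromatic carbon would do remains open, since only hydrogen and fluoro stand there in the compounds shown. Also open, as far as these compounds go, is whether a longer chain or a chain ending in an amine would move the number beyond the scatter.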